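From hydroxy to carboxy on compound 2

The source may report more compounds than this note shows. Statements on the series, on what has been measured and on what is new or still open speak of the compounds shown alone.

Of the compounds shown here, three sharing one core have been tested in a functional assay (mast cells) for inhibition, with Rattus norvegicus as the target; a lower number here means that less compound is needed, a higher number that more compound is needed for the effect. Compound 1 `CC1CC/C(=N\Nc2ccccc2O)c2ncc(C(=O)O)c(=O)n21` gives 208000 nM, compound 2 `CC1CC/C(=N\Nc2ccc(O)cc2)c2ncc(C(=O)O)c(=O)n21` gives 1300 nM, and compound 3 `C[C@@H]1CC/C(=N\Nc2ccc(O)cc2)c2ncc(C(=O)O)c(=O)n21` gives 15600 nM. Compound 2 therefore holds the lowest number of the three, and both of its gaps lie beyond the usual scatter.

Compound 4 `CC1CC/C(=N\Nc2ccc(C(=O)O)cc2)c2ncc(C(=O)O)c(=O)n21` has not yet been measured. It differs from compound 2 in one group: carboxy in place of hydroxy on an aromatic carbon. Carboxy takes the place of hydroxy on an aromatic carbon, para to a large group.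

Within the data shown here, two measured steps bear on this change, both only indirectly. The step of a 160-fold lower number from compound 1 to compound 2 (2.20 log units; beyond the scatter) is large and involves the hydroxy group on this same ring, so this pair shows that the ring can matter a great deal. The step of a 12-fold higher number from compound 2 to compound 3 (1.08 log units; beyond the scatter) is also large, but it comes with the fact that one of compounds 2 and 3 is drawn with a defined configuration and the other without, at the place where they differ and concerns a saturated ring carbon, so it says little about the new group. Neither step replaces hydroxy with another group. Compound 2 already has the lowest number, so a moderate rise seems more likely than a fall, though well short of a 160-fold lower number from compound 1 to compound 2 (2.20 log units; beyond the scatter).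

The step expected in this assay is a 2.3-fold higher number from compound 2 to compound 4 (0.36 log units; beyond the scatter), towards a higher number. For compound 4 the estimated value is 3000 nM, with an expected range from 400 nM to 25000 nM.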

Compound 4, half-maximal effective concentration: 1000000 nM
Estimate against measurement, compound 4: 330-fold (2.52 log units) below; the whole stated range lies below it.
By their numbers in this assay, from the lowest: compound 2; then compound 3; then compound 1; then compound 4.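

In this assay, carboxy in place of hydroxy on an aromatic carbon, para to a large group, gives a 770-fold higher number from compound 2 to compound 4 (2.89 log units; beyond the scatter), a large step. The earlier compounds shown here showed that the place of the hydroxy group on this ring matters, with a 160-fold lower number from compound 1 to compound 2 (2.20 log units; beyond the scatter); they did not show what happens when that group is replaced, and now a single exchange at this position takes the series from its lowest number to its highest. The count of hydrogen-bond donors and acceptors is the same for hydroxy and carboxy, and neither carries a net charge, so those counts do not separate compound 2 from compound 4, and nothing measured here accounts for the size of the step.

The compounds shown leave open whether the rise belongs to carboxy in particular or would also appear with other groups at this position, such as methoxy, an amine or a methyl ester. They also leave open whether the same exchange would give a step of similar size on compound 3, whose stereocentre is drawn as R.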